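The compounds below may be only part of what the source reports. "The series", "measured", "known", "first", "only" and "open" are said of these compounds alone.

Measured so far in a functional assay on SR cells (Homo sapiens) for inhibition, read by sulforhodamine B assay, with a stated time of 48 h; on this read-out lower numbers stand for stronger inhibition of growth and higher numbers for weaker inhibition of growth:

Compound 1 `Cn1cccc1-c1cc(-c2cccs2)nc(N)c1C#N` gives 5370 nM.
Compound 2 `Cn1cccc1-c1cc(-c2cccs2)[nH]c(=O)c1C#N` gives only a limit of the assay, > 100000 nM.
Compound 3 `Cn1cccc1-c1cc(-c2ccccc2)[nH]c(=O)c1C#N` likewise gives only a limit of the assay, > 100000 nM.

The change from compound 2 to compound 3 is phenyl in place of thiophen-2-yl on an aromatic carbon. Its step, a step that the two limits leave unreadable from compound 2 to compound 3, cannot be sized because the limit of > 100000 nM in this assay, at which 2 of the 3 values shown sit, covers both of its ends. How the core of compound 1 differs from the core of compound 2 is not broken down here.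

Compound 4 `Cn1cccc1-c1cc(-c2ccccc2)nc(N)c1C#N` is not yet measured in this assay. It arises from compound 1 by phenyl in place of thiophen-2-yl on an aromatic carbon. The place descriptions differ only in that compound 1 carries an amino group where compound 2 carries a group of 1 heavy atom, so this is the same kind of change rather than the same change. Since the earlier step is unreadable, the expected step from compound 1 to compound 4 in this assay is set near no change, a 1.5-fold higher number from compound 1 to compound 4 (0.17 log units; within the scatter), leaning on the value of compound 1, 5370 nM. Compound 4 is therefore estimated at 8000 nM, with a range from 2000 nM to 40000 nM.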

Compound 4, concentration for 50% growth inhibition: 35500 nM
For compound 4 the middle estimate is 4.4-fold (0.65 log units) below the measured one, and the stated range covers the measured number.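

In this assay, phenyl in place of thiophen-2-yl brings a 6.6-fold higher number from compound 1 to compound 4 (0.82 log units; beyond the scatter), so on this core the change clearly weakens inhibition of growth. The same change on the core of compound 2 cannot be compared with this step, because both of its ends are limits of the assay and not numbers: the limit of > 100000 nM in this assay, at which 2 of the 4 values shown sit. The change therefore has a readable size on one core only, and these results neither show nor rule out that it would have a similar effect on the other core, nor do they explain why it weakens inhibition on the core of compound 1.

The compounds shown leave open whether a furan-2-yl ring or a longer chain, such as butyl, in the same place would give a lower or a higher number than thiophen-2-yl. They also leave open how a dimethylamino group or a carboxylic acid in place of the amino group of compound 1 would change the number.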